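Working notes on two measured amides and one proposed

The source may report more compounds than this note shows. Statements on the series, on what has been measured and on what is new or still open speak of the compounds shown alone.

Measured so far:
compound 1, `CN1CCN(C(=O)/C=C/c2ccncc2-c2ccc3ccccc3c2)CC1`, > 10000 nM
compound 2, `CCOC(=O)/C=C/c1ccncc1-c1ccc2[nH]ccc2c1`, 7440 nM

Compound 1 stands at the limit of > 10000 nM in this assay, at which 1 of the 2 values shown sits; its value in a functional assay on A549 cells (Homo sapiens) for inhibition, read by sulforhodamine B assay, with a stated time of 72 h (on this read-out lower numbers stand for stronger inhibition of growth and higher numbers for weaker inhibition of growth), is a limit of the assay, not a number. Compound 2 gives 7440 nM in this assay, and of this pair nothing beyond the two values can be said.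

Compound 3, `CN(C)C(=O)/C=C/c1ccncc1-c1ccc2ccccc2c1`, remains to be measured in this assay. It differs from compound 1 by dimethylamino in place of 4-methylpiperazin-1-yl on a carbonyl carbon. Given (the limit of > 10000 nM in this assay, at which 1 of the 2 values shown sits), the step that the limit leaves unreadable from compound 1 to compound 3 is expected to be none beyond the scatter. For compound 3 the estimate is 12000 nM, between 4000 nM and 40000 nM, with a fair chance that only a limit is reported again.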

Compound 3, concentration for 50% growth inhibition: 5800 nM
Estimate against measurement, compound 3: 2.1-fold (0.32 log units) above, within the range that was stated.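

In this assay, an amide on this core now carries a number rather than a limit, with dimethylamino in place of 4-methylpiperazin-1-yl on a carbonyl carbon. The change reads as an at least 1.7-fold lower number from compound 1 to compound 3 (0.23 log units; that floor lies within the scatter). Only the floor of this step can be read, not its full size, because compound 1 stands at a limit: the limit of > 10000 nM in this assay, at which 1 of the 3 values shown sits.

Going by these compounds, whether morpholin-4-yl or a carboxylic acid on that carbonyl carbon would move the number beyond the scatter remains open. Also open, on these data alone, is whether the same change would give a comparable step on the core of compound 2.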